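This account rests on a few compounds, and the source may have more. Where it says the series, first, only, none or still open, it means among the compounds named here.

Compound 1 `COc1ccc(-c2cc3ccccc3nc2/C=C/C(=O)c2ccc(F)cc2)cc1` carries a 4-fluorophenyl on a carbonyl carbon whose other neighbour is a double-bonded chain carbon. In a functional assay on NCI-H460 cells (Homo sapiens) for antiproliferative activity, read by XTT assay, with a stated time of 72 h (on this read-out higher numbers stand for weaker inhibition and lower numbers for stronger inhibition), compound 1 gives 6990 nM. Compound 2 `COc1ccc(-c2cc3ccccc3nc2/C=C/C(=O)c2ccc(N)cc2)cc1`, with amino in place of fluoro on an aromatic carbon, gives 7400 nM in this assay, and the step of a 1.1-fold higher number from compound 1 to compound 2 (0.02 log units; within the scatter) is within the scatter, so the two numbers cannot be ordered. Compound 3 `COc1ccc(-c2cc3ccccc3nc2/C=C/C(=O)c2sccc2N)cc1` returns only a limit of the assay, > 10000 nM, in this assay. The steps of an at least 1.4-fold higher number from compound 1 to compound 3 (0.15 log units; that floor lies within the scatter) and an at least 1.3-fold higher number from compound 2 to compound 3 (0.13 log units; that floor lies within the scatter) have floors that lie within the scatter, as recorded by the limit of > 10000 nM in this assay, at which 1 of the 3 values shown sits.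

Compound 4 `COc1ccc(-c2cc3ccccc3nc2/C=C/C(=O)c2c[nH]c3ccccc23)cc1` differs from compound 1 at the same carbonyl carbon: 1H-indol-3-yl in place of 4-fluorophenyl on a carbonyl carbon. Among the compounds with values here, no measured step changes the group on this carbonyl carbon to a fused bicyclic aromatic, so the bearing steps are only the two replacements of the 4-fluorophenyl, neither of which moved this assay beyond the scatter. The step of a 1.0-fold higher number from compound 1 to compound 4 (0.00 log units; within the scatter) is therefore expected to stay within the scatter. Compound 4 is expected to give 7000 nM in this assay, with a range from 2500 nM to 16000 nM.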

Compound 4, half-maximal inhibitory concentration: 8010 nM
Beside the measured number, compound 4's estimate is 1.1-fold (0.06 log units) below it, within the range that was stated.
By their numbers in this assay, from the lowest: compounds 1, 2 and 4 (each within the scatter of the next). At a limit, above all of these: compound 3.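

In this assay, within the data shown here, the 1H-indol-3-yl is the first fused bicyclic aromatic on this carbonyl carbon, larger than the 4-fluorophenyl it replaces and carrying a hydrogen-bond donor that the 4-fluorophenyl lacks, yet neither step leaves the scatter: a 1.1-fold higher number from compound 1 to compound 4 (0.06 log units; within the scatter) and a 1.1-fold higher number from compound 2 to compound 4 (0.03 log units; within the scatter). Compounds 1, 2 and 4 therefore cannot be ordered, so a six-membered aromatic ring of carbon only and a fused pair of aromatic rings give numbers that this read-out does not separate at this place. Compound 3 gives only a limit of the assay. The step of an at least 1.2-fold lower number from compound 3 to compound 4 (0.09 log units; that floor lies within the scatter) cannot be read, because it rests on that limit and its floor lies within the scatter: the limit of > 10000 nM in this assay, at which 1 of the 4 values shown sits.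

The compounds shown leave open whether any group on this carbonyl carbon can move the number beyond the scatter, for example a phenyl ring bearing a carboxylic acid or a morpholine. They also leave open whether a methyl group on the indole nitrogen, which would remove the amide-like hydrogen there, changes the result, and whether changes elsewhere on the shared core matter more than changes at this place.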